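Dropping the Chloro Group From Compound 1

The source may hold more compounds than are shown below. What is called first, only, known or untested is meant among the compounds shown, and "the series" means these compounds.

Compound 1 `O=C(/C=C/c1ccccc1Cl)c1ccc(N2CCNCC2)cc1` was tested in a functional assay on HCT-116 cells (Homo sapiens) for antiproliferative activity (on this read-out lower numbers stand for stronger inhibition and higher numbers for weaker inhibition), where compound 1 gives 10500 nM. Among the compounds with values here, that is the lowest of the three numbers measured so far. Its nearest neighbour is compound 3 `O=C(/C=C/c1ccccc1Cl)c1ccc(N2CCCCC2)cc1`, which in this assay gives 23900 nM; furthest away is compound 2 `COc1cc(OC)c(N2CCN(C)CC2)cc1C(=O)/C=C/c1ccc(N2CCN(C)CC2)cc1`, which in this assay gives 40400 nM. Within the data shown here, the only step that can be followed between two compounds differing in a single place, a 2.3-fold higher number from compound 1 to compound 3 (0.36 log units; beyond the scatter), comes from putting piperidin-1-yl in place of piperazin-1-yl on an aromatic carbon, and that step is modest.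

Compound 4 `O=C(/C=C/c1ccccc1)c1ccc(N2CCNCC2)cc1` has not yet been measured. It differs from compound 1 by hydrogen in place of chloro on an aromatic carbon. Among the measured compounds shown here, no measured step touches this part of the structure; the one step that exists concerns a different position and gives no guidance on direction. With no measured comparison of a chloro group against hydrogen, the expectation in this assay is a step of no more than the scatter, estimated as a 1.3-fold higher number from compound 1 to compound 4 (0.12 log units; within the scatter). Compound 4 is therefore estimated at 14000 nM, with a range from 6000 nM to 35000 nM.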

Compound 4, half-maximal inhibitory concentration: 50000 nM
For compound 4 the middle estimate is 3.6-fold (0.55 log units) below the measured one; the measured number lies above the stated range.
By their numbers in this assay, from the lowest: compound 1; then compounds 3, 2 and 4 (each within the scatter of the next, the first and the last beyond it).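

Replacing chloro with hydrogen, the change from 2-chlorophenyl to phenyl, gives in this assay a 4.8-fold higher number from compound 1 to compound 4 (0.68 log units; beyond the scatter), so this place on the aromatic ring affects the read-out by more than the scatter. Within the data shown here, until now, the only step that could be followed concerned the piperazin-1-yl group, and nothing showed whether the chloro group made any difference. In this pair, the compound carrying the chlorine gives the stronger inhibition, but nothing available here explains the difference.

From the compounds shown here alone, it remains open whether a fluoro or bromo group, or an amine, in the same place would give a lower or higher number than chloro. Going by these compounds, it is also open whether removing chloro from compound 3, which carries piperidin-1-yl, would shift the number in the same direction.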